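Amide substituent changes on a pyrrole carboxamide series

The compounds below may be only part of what the source reports. "The series", "measured", "known", "first", "only" and "open" are said of these compounds alone.

Measured so far:
- compound 1 `CCn1c(C(=O)N[C@@H](CC(=O)OC)C(=O)OC)ccc1C(CC)(CC)c1ccc(OCS(=O)(=O)c2ccccc2)c(C)c1`: > 50000 nM
- compound 2 `CCn1c(C(=O)N[C@H](C)CO)ccc1C(CC)(CC)c1ccc(OCS(=O)(=O)c2ccccc2)c(C)c1`: 10600 nM
- compound 3 `CCn1c(C(=O)N[C@@H](C)C(=O)O)ccc1C(CC)(CC)c1ccc(OCS(=O)(=O)c2ccccc2)c(C)c1`: 35500 nM

Among the measured compounds shown here, in a functional assay on MCF7 cells (Homo sapiens) for antiproliferative activity, read by MTT assay, with a stated time of 24 h (a higher number here means a weaker inhibitor, a lower number a stronger inhibitor), compound 1 gives only a limit, > 50000 nM, not a number; it is the one value of the three that sits at the assay ceiling (the limit of > 50000 nM in this assay, at which 1 of the 3 values shown sits). Compound 2 gives 10600 nM in this assay. Compound 3 gives 35500 nM in this assay.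

The step of interest leads to compound 4 `CCn1c(C(=O)NC2(C(=O)O)CC2)ccc1C(CC)(CC)c1ccc(OCS(=O)(=O)c2ccccc2)c(C)c1`, which carries 1-carboxycyclopropyl in place of 1,2-bis(methoxycarbonyl)ethyl on an amide-type nitrogen.

For the measured compounds named here, three measured steps bear on it. an at least 4.7-fold lower number from compound 1 to compound 2 (0.67 log units; beyond the scatter) and an at least 1.4-fold lower number from compound 1 to compound 3 (0.14 log units; that floor lies within the scatter) show that replacing the diester with smaller, free hydroxyl- or carboxyl-bearing groups lowers the number, the acid less clearly so. a 3.3-fold higher number from compound 2 to compound 3 (0.52 log units; beyond the scatter) puts the carboxylic acid above the alcohol. Compound 4 carries a carboxylic acid on a three-membered ring, closest in kind to compound 3, so a number near that of compound 3 is expected, with only a small drop from the ceiling of compound 1.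

Compound 4 is therefore estimated at 35000 nM, range 12000 nM to 60000 nM, meaning an at least 1.4-fold lower number from compound 1 to compound 4 (0.15 log units; that floor lies within the scatter) is expected.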

Compound 4, half-maximal inhibitory concentration: 41200 nM
Estimate against measurement, compound 4: 1.2-fold (0.07 log units) below; the range from low to high includes it.
By their numbers in this assay, from the lowest: compound 2; then compounds 3 and 4 (each within the scatter of the next). At a limit, above all of these: compound 1.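

In this assay, the 1-carboxycyclopropyl group cannot be told apart from the 1-carboxyethyl group: a 1.2-fold higher number from compound 3 to compound 4 (0.06 log units; within the scatter), so at this place on the amide-type nitrogen the three-membered ring gives no reading of its own against the open-chain acid. The gap to the alcohol appears again with this second acid, a 3.9-fold higher number from compound 2 to compound 4 (0.59 log units; beyond the scatter), and among the compounds shown both carboxylic acids, compound 3 and compound 4, carry higher numbers than the 1-(hydroxymethyl)ethyl compound 2, with none going against this. Compound 1 is only a limit, so the reading against the diester is no more than a floor, an at least 1.2-fold lower number from compound 1 to compound 4 (0.08 log units; that floor lies within the scatter), and the order of compound 4 and compound 1 stays unsettled: the limit of > 50000 nM in this assay, at which 1 of the 4 values shown sits.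

Open, going by these compounds, is whether a 1-(hydroxymethyl)cyclopropyl group would keep the number of compound 2, which would show whether the ring is as silent with an alcohol as it is with an acid. Open too, on these data alone, is how a primary carboxamide, an amine or a methyl ester of a single carboxyl group would read on the same nitrogen, and so whether the gap belongs to the free carboxylic acid itself.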